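Shortening the acyl chain in a chemokine receptor binder

A few compounds are considered here, and "the series" means these few. Any claim that something is new, unique, unknown or untested is made for them only; others in the source may bear on it.

Compound 1, `Cc1ccccc1CCC(=O)N[C@@H](C(=O)N1CCC(c2ccc(Cl)cc2)CC1)C(C)C`, gives 19 nM in an assay on THP-1 cells for displacement of a labelled ligand from C-C chemokine receptor type 1 (Homo sapiens); a lower number here means a stronger inhibitor, a higher number a weaker inhibitor.
Compound 2, `CC[C@@H](NC(=O)CC(C)C)C(=O)N1CCC(c2ccc(Cl)cc2)CC1`, gives 152 nM in this assay.

Of the two measured compounds, compound 1 has the lower number in this assay, and the gap between compound 1 and compound 2 lies beyond the usual scatter of this measurement, so compound 1 is the stronger binder of the pair. Compound 3, `Cc1ccccc1C(=O)N[C@@H](C(=O)N1CCC(c2ccc(Cl)cc2)CC1)C(C)C`, has not yet been measured. It differs from compound 1 in a single place: 2-methylphenyl in place of 2-(2-methylphenyl)ethyl on a carbonyl carbon. The aromatic ring is thus attached directly to the carbonyl carbon rather than through a two-carbon linker, so the acyl part is shorter and stiffer. Going by the values given here, no measured pair shows the effect of this particular change, and the step from compound 2 to compound 1 involves several changes at once, so it cannot be read as a guide. The expectation is a moderate weakening, with the step of a 3.2-fold higher number from compound 1 to compound 3 (0.50 log units; beyond the scatter) estimated to exceed the scatter. Compound 3 is expected to give about 60 nM in this assay, within a range of 15 nM to 250 nM.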

Compound 3, half-maximal inhibitory concentration: 32 nM
Compound 3: the middle estimate sits 1.9-fold (0.27 log units) above what was measured; measured number inside the range.
By their numbers in this assay, from the lowest: compounds 1 and 3 (each within the scatter of the next); then compound 2.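

In this assay, putting 2-methylphenyl in place of 2-(2-methylphenyl)ethyl on the carbonyl carbon comes with a 1.7-fold higher number from compound 1 to compound 3 (0.23 log units; within the scatter), so the two numbers cannot be told apart in this measurement. Going by these compounds alone, this is the first direct reading at this position: the group on the carbonyl carbon can go from 9 heavy atoms to 7, keeping its aromatic ring, with no difference that stands clear of the usual scatter. For this pair, then, the extra carbons of 2-(2-methylphenyl)ethyl are not needed to keep a number comparable to that of compound 1, although nothing measured here explains why.

Going by these compounds, what remains open is how binding would respond on this same carbonyl carbon to a plain phenyl, a 2-methylbenzyl or a longer chain, any of which would show whether the methyl group or the length of the acyl part matters at all. Also open, on these data alone, is what a carboxylic acid or an amine on the aromatic ring of compound 3 would do to the number in this assay.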